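Isopropoxy in place of propargyloxy on a shared core

The source may hold more compounds than are shown below. What is called first, only, known or untested is meant among the compounds shown, and "the series" means these compounds.

The compounds share one core and differ only in the group on the oxygen on the aromatic ring. Compound 1 `CCCOc1ccc(-c2cn3c(=O)n(-c4ccccc4)nc3c(N)n2)cc1` carries a propoxy group, compound 2 `C=CCOc1ccc(-c2cn3c(=O)n(-c4ccccc4)nc3c(N)n2)cc1` an allyloxy group, and compound 3 `C#CCOc1ccc(-c2cn3c(=O)n(-c4ccccc4)nc3c(N)n2)cc1` a propargyloxy group. In an assay on cells for displacement of a labelled ligand from adenosine receptor A1 (Homo sapiens), read by scintillation counting, with a stated time of 3 h (on this read-out lower numbers stand for stronger inhibition and higher numbers for weaker inhibition), compound 1 gives only a limit, > 30000 nM, which is not a number. For compound 2 no result in this assay was reported, "not determined" (no result reported). In this assay compound 3 likewise gives only a limit, > 30000 nM. Compound 3 thus stands at the edge of what the measurement can report, with no numbered neighbour around it.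

Compound 4 `CC(C)Oc1ccc(-c2cn3c(=O)n(-c4ccccc4)nc3c(N)n2)cc1` differs from compound 3 by isopropyl in place of propargyl on an oxygen on an aromatic ring. Within the data shown here, the one measured step that bears on this position is the change from a propoxy to a propargyloxy group, a step that the two limits leave unreadable from compound 1 to compound 3, and because both of its ends rest at the limit of > 30000 nM in this assay, at which 2 of the 3 values shown sit, its size is unreadable. Nothing measured here points to a gain in binding from any small group on that oxygen. The step that the limit leaves unreadable from compound 3 to compound 4 is therefore expected to be none beyond the scatter. Compound 4 is expected to return about 50000 nM, estimated between 15000 nM and 200000 nM, most likely again as a limit rather than a number.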

Compound 4, inhibition constant: > 30000 nM
Compound 4: no number, only a limit; the forecaster's own chance of this, stated with the estimate: 85%; the middle value lies beyond the limit too.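

In this assay compound 4 gives > 30000 nM as a limit and not a number. No step from compound 1 or compound 3 to compound 4 can be read, because these compounds all rest at the same limit: the limit of > 30000 nM in this assay, at which 3 of the 4 values shown sit.

The compounds shown leave open whether any group on this oxygen gives a measurable value in this assay at all.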